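This account rests on a few compounds, and the source may have more. Where it says the series, first, only, none or still open, it means among the compounds named here.

Two compounds have so far been run in a functional assay on the whole organism (strain CD1) for inhibition, with Mus musculus as the target, with stated times of 15 min and 20 min, at a dose of 10 mg/kg by the subcutaneous route; on this read-out lower numbers stand for less inhibition and higher numbers for more inhibition at the one dose given (going by the name of the read-out). Compound 1 `N#C/C(=C\c1ccccc1)C(=O)OC1CCCCC1` gives 7.1% in this assay. Within the data shown here, compound 2 `CCOC(=O)/C(C#N)=C/c1ccc[nH]1` gives 25.8% in this assay, the higher of the two numbers; its only neighbour, compound 1, sits a good deal lower, by a gap that is beyond the usual scatter of such measurements. Compounds 1 and 2 differ in two places at once, so the numbers alone cannot say which of the two changes carries that gap.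

Compound 3 `N#C/C(=C\c1ccc[nH]1)C(=O)OC1CCCCC1` combines one piece of each: it keeps the ring of compound 2 and takes the ester of compound 1. The change from compound 2 is cyclohexyl in place of ethyl on an oxygen next to a carbonyl group. Among the measured compounds shown here, no measured pair here isolates this swap, so its direction is not known from the data. Compound 1, which carries the same cyclohexyl on the same oxygen, gives only 7.1%, which argues for caution. The expected step is therefore a number 8.8 percentage points lower from compound 2 to compound 3 (within the scatter), a modest drop that may or may not clear the scatter. Compound 3 is expected to give 17%, within a range from 3% to 38%.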

Compound 3, a percentage reported as inhibition, in the whole organism at one dose (the size of the read-out at that dose, not a potency): 10%
Compound 3: middle estimate off by 7 percentage points, on the high side; the range from low to high includes it.
By their numbers in this assay, from the lowest: compounds 1 and 3 (each within the scatter of the next); then compound 2.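

In this assay, the ester change now stands alone: with the ring held the same, cyclohexyl in place of ethyl on an oxygen next to a carbonyl group gives a number 15.8 percentage points lower from compound 2 to compound 3 (beyond the scatter), so on this core the ethyl compound holds the higher number. The other single change, 1H-pyrrol-2-yl in place of phenyl on a double-bonded chain carbon bound to a double-bonded chain carbon, gives a number 2.9 percentage points higher from compound 1 to compound 3 (within the scatter), so with cyclohexyl on the oxygen this ring swap does not move the number past the usual spread of repeat measurements. No measurement available here gives a reason for either step.

The compounds shown leave open what the same ring swap does when ethyl, rather than cyclohexyl, sits on the oxygen, since that pair cannot be read from them. They also leave open where a longer chain such as butyl, or a benzyl group, on that same oxygen would fall relative to ethyl and cyclohexyl, and all of these numbers describe one dose, not a potency.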